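Lengthening the methyl of compound 3 to propyl

The compounds below may be only part of what the source reports. "The series", "measured", "known", "first", "only" and "open" are said of these compounds alone.

Measured in an in vitro ADME assay on microsomes from liver (Rattus norvegicus) for metabolic stability; on this read-out lower numbers stand for a shorter-lived compound and higher numbers for a longer-lived compound:
- compound 1 `Cc1nc(CN2CCN(c3cccc4[nH]c(-c5ccc(C(C)(C)C)cc5)nc34)CC2)c[nH]1`: > 0.5 h (a limit)
- compound 2 `CCCCn1cnc(CN2CCN(c3cccc4[nH]c(-c5ccc(C(C)(C)C)cc5)nc34)CC2)c1C`: > 0.5 h (a limit)
- compound 3 `Cc1nc(CN2CCN(c3cccc4[nH]c(-c5ccc(C(C)(C)C)cc5)nc34)CC2)cn1C`: 0.15 h

Among the measured compounds shown here, compound 3 gives 0.15 h, the only true number. Compound 1 and compound 2 stand at the limit of > 0.5 h in this assay, at which 2 of the 3 values shown sit.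

Compound 4 `CCCn1cc(CN2CCN(c3cccc4[nH]c(-c5ccc(C(C)(C)C)cc5)nc34)CC2)nc1C` differs from compound 3 by ethyl in place of hydrogen on a saturated chain carbon bound to an aromatic nitrogen, which turns methyl into propyl.

For the measured compounds named here, two measured steps bear on this. The first is an at least 3.3-fold lower number from compound 1 to compound 3 (0.52 log units; beyond the scatter), with methyl in place of hydrogen on an aromatic nitrogen. The closer one is an at least 3.3-fold lower number from compound 2 to compound 3 (0.52 log units; beyond the scatter), where 1,2-dimethyl-1H-imidazol-4-yl replaces 1-butyl-5-methyl-1H-imidazol-4-yl. Read in reverse, this second step pairs butyl with the higher reading, but those two groups differ in more than the chain, so it is only a partial guide.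

The expected change is a 2.0-fold higher number from compound 3 to compound 4 (0.30 log units; within the scatter), a small upward step. For compound 4 the estimate is 0.3 h, with an expected range of 0.1 h to 0.8 h.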

Compound 4, half-life: 0.417 h
For compound 4 the middle estimate is 1.4-fold (0.14 log units) below the measured one; the measured number falls inside the stated range.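

In this assay, the chain on the aromatic nitrogen now has a step with true numbers at both ends: a 2.8-fold higher number from compound 3 to compound 4 (0.44 log units; beyond the scatter). This step is printed as beyond the scatter, whereas each earlier step here ran against a limit. Against the limit compounds only floors can be read, and both lie within the scatter: an at least 1.1-fold lower number from compound 2 to compound 4 (0.07 log units; that floor lies within the scatter), and an at least 1.1-fold lower number from compound 1 to compound 4 (0.07 log units; that floor lies within the scatter). Compound 1 and compound 2 remain limits, not numbers: the limit of > 0.5 h in this assay, at which 2 of the 4 values shown sit.

Going by these compounds, whether a butyl chain alone, a branched isopropyl or a hydroxyethyl group at this place would move the reading further stays open, since compound 2 differs from compound 4 in more than the chain. On these data alone, the true distance of compound 1 and compound 2 from compound 4 also stays open.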